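Trading a Propylphenyl Ring for a Chlorophenyl Ring

The source may report more compounds than this note shows. Statements on the series, on what has been measured and on what is new or still open speak of the compounds shown alone.

Compound 1 `CCCc1ccc(/C=C/C(=O)Nc2ccc3nc(CCC)cc(N)c3c2)cc1` was examined in an assay on isolated protein for displacement of a labelled ligand from melanin-concentrating hormone receptor 1 (Homo sapiens) (on this read-out higher numbers stand for weaker inhibition and lower numbers for stronger inhibition), where compound 1 gives 4 nM. Among the three measured compounds it holds the second highest number. Compound 3 `CCCc1cc(N)c2cc(NC(=O)C3CCC(c4ccc(Cl)cc4)CC3)ccc2n1` lies nearest: in this assay compound 3 gives 4.4 nM, a gap that stays within the usual scatter. Compound 2 `CC(C)(C)c1cc(N)c2cc(NC(=O)/C=C/c3ccc(C(F)(F)F)cc3)ccc2n1` lies furthest away, as in this assay compound 2 gives 0.3 nM, a gap that goes beyond the scatter.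

The unmeasured compound 4 `CCCc1cc(N)c2cc(NC(=O)/C=C/c3cccc(Cl)c3)ccc2n1` shares the core of compound 1 and differs from it in one place: 3-chlorophenyl in place of 4-propylphenyl on a double-bonded chain carbon bound to a double-bonded chain carbon. Going by the values given here, no measured pair mirrors this change, so the expectation rests on the spread of the three numbers. Compound 2 and compound 3 show that other aryl groups keep strong binding, but neither carries the 3-chlorophenyl group, and a smaller ring than the one it replaces is an untested direction here. A modest step, if any, is expected, more likely towards a higher number than a lower one, and quite possibly within the scatter. The step from compound 1 to compound 4 is estimated as a 1.5-fold higher number from compound 1 to compound 4 (0.18 log units; within the scatter). Compound 4 is accordingly expected to give 6 nM in this assay, within a range from 2 nM to 20 nM.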

Compound 4, half-maximal inhibitory concentration: 1100 nM
Beside the measured number, compound 4's estimate is 180-fold (2.26 log units) below it; the measured number lies above the stated range.
By their numbers in this assay, from the lowest: compound 2; then compounds 1 and 3 (each within the scatter of the next); then compound 4.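

In this assay, exchanging 4-propylphenyl for 3-chlorophenyl on a double-bonded chain carbon bound to a double-bonded chain carbon gives a 280-fold higher number from compound 1 to compound 4 (2.44 log units; beyond the scatter), so this one place on the shared core is far from indifferent to the aryl group it carries. The earlier compounds shown here could not show this, as no step between compounds differing in one place was available among them, whereas here a single exchange separates the two numbers. The exchange alters both the substituent and its place on the phenyl ring, and nothing available explains the step or assigns it to either alteration.

The compounds shown leave open whether 4-chlorophenyl at this place would stay close to compound 1 or follow compound 4, and the same question holds for 3-propylphenyl, which would help separate the effect of the substituent from that of its place on the ring. Also open, from the compounds shown here alone, is how an unsubstituted phenyl, a 4-ethylphenyl or a 4-methoxyphenyl group would fare on the same chain carbon.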